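Moving the nitro group around the phenyl ring of compound 3

The source may report more compounds than this note shows. Statements on the series, on what has been measured and on what is new or still open speak of the compounds shown alone.

Measured compounds:
compound 1, `COc1ccc(C2SCC(=O)N2c2ccc3c(C)cc(=O)[nH]c3c2)cc1`, 21.4%
compound 2, `COc1cc(C2SCC(=O)N2c2ccc3c(C)cc(=O)[nH]c3c2)ccc1O`, 12.4%
compound 3, `Cc1cc(=O)[nH]c2cc(N3C(=O)CSC3c3ccccc3[N+](=O)[O-])ccc12`, 24.1%

In a functional assay on the whole organism (strain albino) for inhibition, with Rattus norvegicus as the target, read by paw edema, with stated times of 1 h and 3 h, at a dose of 100 mg/kg by the oral route (on this read-out higher numbers stand for more inhibition at the one dose given (going by the name of the read-out) and lower numbers for less inhibition), compound 3 gives the largest of the three numbers, but its gap to compound 1 lies within the scatter and only its gap to compound 2 lies beyond it, so no ordering of compound 3 against compound 1 is claimed. Compound 4, `Cc1cc(=O)[nH]c2cc(N3C(=O)CSC3c3ccc([N+](=O)[O-])cc3)ccc12`, differs from compound 3 only in the aryl group on the saturated ring carbon: 4-nitrophenyl in place of 2-nitrophenyl on a saturated ring carbon. Going by the values given here, the steps that bear on this place are a number 2.7 percentage points higher from compound 1 to compound 3 (within the scatter) and a number 11.7 percentage points higher from compound 2 to compound 3 (beyond the scatter), together with a number 9 percentage points lower from compound 1 to compound 2 (within the scatter). All three exchange one aryl group for another at the same carbon, and only one of them moves the number beyond the scatter. None of them moves a nitro group from one position of the phenyl ring to another. On that basis the step of a number 2.1 percentage points lower from compound 3 to compound 4 (within the scatter) is expected to stay within the scatter, with no direction favoured. Compound 4 is therefore estimated to give 22%, with a range from 10% to 34% in this assay.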

Compound 4, a percentage reported as inhibition, in the whole organism at one dose (the size of the read-out at that dose, not a potency): 25.2%
Compound 4: the middle estimate sits 3.2 percentage points below what was measured, and the stated range covers the measured number.
By their numbers in this assay, from the lowest: compounds 2, 1, 3 and 4 (each within the scatter of the next, the first and the last beyond it).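

Moving the nitro group on this phenyl ring, with 4-nitrophenyl in place of 2-nitrophenyl on the saturated ring carbon, gives a number 1.1 percentage points higher from compound 3 to compound 4 (within the scatter), so in this assay the two placements cannot be told apart. Both nitrophenyl compounds stand clear of the 4-hydroxy-3-methoxyphenyl compound, as shown by a number 11.7 percentage points higher from compound 2 to compound 3 (beyond the scatter) and by a number 12.8 percentage points higher from compound 2 to compound 4 (beyond the scatter). Nitro in place of methoxy on the aromatic carbon gives a number 3.8 percentage points higher from compound 1 to compound 4 (within the scatter), so this exchange cannot be read as a change either.

Nothing at hand accounts for these numbers. On these data alone, whether an amine or a carboxylic acid in place of the nitro group on this phenyl ring would move the number beyond the scatter from compound 4 remains open.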